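The source may report more compounds than this note shows. Statements on the series, on what has been measured and on what is new or still open speak of the compounds shown alone.

For the measured compounds named here, compound 3 `ClCc1cccc(Cn2cnc3c(Cl)ncnc32)c1` is the one compound of the three for which a functional assay on MOLT-4 cells (Homo sapiens) for cytotoxicity, read by sulforhodamine B assay, with a stated time of 48 h (a lower number here means a stronger inhibitor of growth, a higher number a weaker inhibitor of growth), returns a number: in this assay compound 3 gives 37200 nM. Compound 1 `ClCc1ccc(Cn2cnc3c(Cl)ncnc32)cc1` reaches only the limit of the assay, giving > 100000 nM in this assay. Compound 2 `Nc1nc(Cl)c2ncn(Cc3ccc(CCl)cc3)c2n1` likewise gives > 100000 nM in this assay, a limit and not a number. Compound 4 `Nc1nc(Cl)c2ncn(Cc3cccc(CCl)c3)c2n1` differs from compound 3 by amino in place of hydrogen on an aromatic carbon. Going by the values given here, the one measured step of the same kind, a step that the two limits leave unreadable from compound 1 to compound 2, cannot be read because of the limit of > 100000 nM in this assay, at which 2 of the 3 values shown sit. Among the compounds with values here, no measured step therefore fixes the size of the change to compound 4. The step that is expected is a 1.2-fold higher number from compound 3 to compound 4 (0.08 log units; within the scatter), an estimate and not a measurement. Compound 4 is expected to give 45000 nM in this assay, with a range from 12000 nM to 150000 nM.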

Compound 4, concentration for total growth inhibition: > 100000 nM
Compound 4 ended at the assay's limit (the forecaster's own chance of this, stated with the estimate: 35%); middle value at least 2.2-fold (0.34 log units) from the limit.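

In this assay, amino in place of hydrogen on the aromatic carbon between two ring nitrogen atoms gives an at least 2.6-fold higher number from compound 3 to compound 4 (0.42 log units; beyond the scatter). For the compounds shown here, this is the first readable size for this change, and it points towards weaker growth inhibition, though only as a lower bound, since compound 4 sits at a limit. The same change from compound 1 to compound 2 still cannot be read: the limit of > 100000 nM in this assay, at which 3 of the 4 values shown sit.

Going by these compounds, the true size of the step stays open. So does whether a methylamino or a methoxy group on that carbon would act as amino does.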